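A Bridged Ring Gives Way to a Hydroxyl-Bearing Chain

A few compounds are considered here, and "the series" means these few. Any claim that something is new, unique, unknown or untested is made for them only; others in the source may bear on it.

Compound 1 `CCCn1c(=O)c2nc(CC(C)(C)C)[nH]c2n(CCC)c1=O` gives 49 nM in an assay on cell membranes for binding affinity to adenosine receptor A1 (Cavia porcellus), read by radioligand binding; a higher number here means a weaker inhibitor, a lower number a stronger inhibitor.
Compound 2 `CCCn1c(=O)c2nc(C(C)(C)CCC)[nH]c2n(CCC)c1=O` gives 25 nM.
Compound 3 `CCCn1c(=O)c2nc([C@@H]3CC4CCC3C4)[nH]c2n(CCC)c1=O` gives 3.8 nM.

Compound 3 stands lowest of the three numbers, and its separations from the other two are beyond the scatter. Compound 4 `CCCn1c(=O)c2nc(C(O)(CC)CC)[nH]c2n(CCC)c1=O` differs from compound 3 in one place: a group of 6 heavy atoms (5 carbon, 1 oxygen; no ring) in place of a group of 7 heavy atoms (7 carbon; 2 five-membered non-aromatic rings of carbon only), on an aromatic carbon. Among the measured compounds shown here, the steps that bear on this change are those in which the two fused rings replaced an open chain, a 13-fold lower number from compound 1 to compound 3 (1.11 log units; beyond the scatter) and a 6.6-fold lower number from compound 2 to compound 3 (0.82 log units; beyond the scatter), one large and one modest. For the measured compounds named here, compound 4 undoes that kind of change, while the hydroxyl group has no counterpart among the measured compounds. A step to a higher number, back toward the region of compound 1 and compound 2, is therefore expected in this assay. Compound 4 is estimated at 40 nM, within 12 nM to 150 nM, which would mean an 11-fold higher number from compound 3 to compound 4 (1.02 log units; beyond the scatter).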

Compound 4, inhibition constant: 170 nM
Compound 4: middle estimate off by 4.3-fold (0.63 log units), on the low side; measured number above the stated range.
By their numbers in this assay, from the lowest: compound 3; then compounds 2 and 1 (each within the scatter of the next); then compound 4.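

Moving from the two-ring group to 1-ethyl-1-hydroxypropyl in this assay gives a 45-fold higher number from compound 3 to compound 4 (1.65 log units; beyond the scatter), a larger step than either earlier change between that two-ring group and an open chain. The hydroxyl-bearing chain also stands above both open chains without a hydroxyl, with a 6.8-fold higher number from compound 2 to compound 4 (0.83 log units; beyond the scatter) and a 3.5-fold higher number from compound 1 to compound 4 (0.54 log units; beyond the scatter), so an open chain at this aromatic carbon does not by itself fix the number. No outside measurement here bears on this result. As far as these compounds go, whether the hydroxyl or the two ethyl branches go with the rise stays open, and a 1-ethyl-1-methylpropyl group, or an amine in the hydroxyl's place, would bear on that.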